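This account rests on a few compounds, and the source may have more. Where it says the series, first, only, none or still open, it means among the compounds named here.

Compound 1, `O=C1/C(=C/c2ccc(Cl)cc2Cl)CCCc2ccccc21`, gives > 500000 nM in a functional assay on Molt4/C8 cells (Homo sapiens) for inhibition; a lower number here means a stronger inhibitor, a higher number a weaker inhibitor.
Compound 2, `O=C1/C(=C/c2ccccc2F)CCc2ccccc21`, gives 36000 nM.

For compound 1 the value is a limit of the assay and not a number (the limit of > 500000 nM in this assay, at which 1 of the 2 values shown sits). Among the measured compounds shown here, compound 2 thus holds the only number in this set. Compound 3, `Cc1ccccc1/C=C1\CCc2ccccc2C1=O`, differs from compound 2 by methyl in place of fluoro on an aromatic carbon. For the measured compounds named here, no measured step of this kind is available here. The change is expected to move this assay by a 1.1-fold higher number from compound 2 to compound 3 (0.05 log units; within the scatter), a step expected to remain within the usual scatter. Compound 3 is therefore estimated at 40000 nM, with a range from 10000 nM to 160000 nM.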

Compound 3, half-maximal inhibitory concentration: 41400 nM
Compound 3: middle estimate off by 1.0-fold (0.01 log units), on the low side; the measured number falls inside the stated range.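

Methyl in place of fluoro on an aromatic carbon, ortho to a large group, now has a measured step in this assay, and that step is a 1.2-fold higher number from compound 2 to compound 3 (0.06 log units; within the scatter). At this position, therefore, the assay does not tell the two groups apart, which a single number at this place could not show. On these data alone, whether an amine, a carboxylic acid or a longer chain at the same position would give a step beyond the scatter stays open. Nothing measured among these compounds offers a reason for the result.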